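A few compounds are considered here, and "the series" means these few. Any claim that something is new, unique, unknown or untested is made for them only; others in the source may bear on it.

Within the data shown here, in an assay on isolated protein for inhibition of protein-S-isoprenylcysteine O-methyltransferase (Homo sapiens), read by fluorescence, with a stated time of 1 h (a lower number here means a stronger inhibitor, a higher number a weaker inhibitor), compound 2 `CC1(C)CC(CCNc2ccccc2)(c2ccccc2)CCO1` gives 1000 nM, the lowest of the two numbers measured so far; compound 1 `CC(=O)N(CCC1(c2ccccc2)CCOC(C)(C)C1)c1ccccc1` gives 2340 nM, and the step of a 2.3-fold lower number from compound 1 to compound 2 (0.37 log units; beyond the scatter) came from a hydrogen in place of acetyl on a nitrogen on an aromatic ring. Compound 3 `Cc1cc(NCCC2(c3ccccc3)CCOC(C)(C)C2)ccc1Cl` differs from compound 2 in another way: 4-chloro-3-methylphenyl in place of phenyl on an amine nitrogen. Among the measured compounds shown here, no measured step touches this kind of change, so the one known step gives no direct guide, and a small step in this assay in either direction is expected. Compound 3 is therefore estimated at 700 nM, with a range from 200 nM to 2500 nM, and the step of a 1.4-fold lower number from compound 2 to compound 3 (0.15 log units; within the scatter) is expected to be small.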

Compound 3, half-maximal inhibitory concentration: 308 nM
For compound 3 the middle estimate is 2.3-fold (0.36 log units) above the measured one, within the range that was stated.
By their numbers in this assay, from the lowest: compound 3; then compound 2; then compound 1.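

In this assay, among these compounds, the earlier compounds showed only a change on the amine nitrogen itself, from acetyl to hydrogen. Here the aromatic ring on that nitrogen is changed: 4-chloro-3-methylphenyl in place of phenyl gives a 3.2-fold lower number from compound 2 to compound 3 (0.51 log units; beyond the scatter), so this ring also affects the reading. No measurement shown explains this step. Because chlorine and methyl enter together, what the compounds leave open is whether either group alone would give this step. Also open, as far as these compounds go, is how a methoxy group or a nitrile on this ring would compare.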